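Swapping methoxy for nitro in compound 2

The compounds below may be only part of what the source reports. "The series", "measured", "known", "first", "only" and "open" are said of these compounds alone.

Compound 1 `CC(C)(C)NCc1c(C(=O)O)nn(-c2ccccc2)c1-c1ccc([N+](=O)[O-])cc1` – > 634000 nM (a limit of the assay)
Compound 2 `COc1ccc(-c2c(CNC(C)(C)C)c(C(=O)O)nn2-c2ccc(Cl)cc2)cc1` – 498000 nM

For the measured compounds named here, in a functional assay on U-251 cells (Homo sapiens) for inhibition, read by sulforhodamine B assay, with a stated time of 48 h (on this read-out lower numbers stand for stronger inhibition of growth and higher numbers for weaker inhibition of growth), compound 2 gives 498000 nM, the only actual number so far. Compound 1 gives > 634000 nM, which is a limit of the assay and not a number.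

Compound 3 `CC(C)(C)NCc1c(C(=O)O)nn(-c2ccc(Cl)cc2)c1-c1ccc([N+](=O)[O-])cc1` has not yet been measured. It is compound 2 with nitro in place of methoxy on an aromatic carbon, para to a large group, so that 4-methoxyphenyl becomes 4-nitrophenyl (nitro in place of methoxy on an aromatic carbon).

Going by the values given here, no pair of measured compounds differs in one place only, so the data give no direct size for such a step. In this assay no step beyond the scatter is expected, and no direction can be favoured. This expectation starts from compound 2 at 498000 nM and assumes that growth inhibition stays weak. The estimated step of a 1.0-fold lower number from compound 2 to compound 3 (0.02 log units; within the scatter) is expected to stay within the scatter. Compound 3 is estimated at 480000 nM, with an expected range from 220000 nM to 800000 nM.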

Compound 3, concentration for 50% growth inhibition: > 583000 nM
Compound 3: only a limit was reported (the forecaster's own chance of this, stated with the estimate: 50%); middle value at least 1.2-fold (0.08 log units) from the limit.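

Nitro in place of methoxy, on an aromatic carbon para to a large group, gives an at least 1.1-fold higher number from compound 2 to compound 3 (0.06 log units; that floor lies within the scatter) in this assay, and that floor offers no sign of stronger inhibition of growth from this change. Compound 3 pairs the 4-nitrophenyl group with chloro and gives only a limit of the assay, as compound 1 does, so the step between them, chloro in place of hydrogen, cannot be read. The reading for compound 3 is therefore a limit and not a number: the limit of > 583000 nM in this assay, at which 1 of the 3 values shown sits.

Going by these compounds, how far the true value of compound 3 lies from that limit stays open, and so does the real size of the step from methoxy to nitro. The compounds shown also leave open how a hydroxy group, an amino group or a longer chain such as ethoxy would read at this same place.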